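Working notes: methoxy for fluoro on compound 2

A few compounds are considered here, and "the series" means these few. Any claim that something is new, unique, unknown or untested is made for them only; others in the source may bear on it.

Measured in an ADME assay on PBMC cells (Homo sapiens) for cytotoxicity, read by MTT assay, with a stated time of 72 h, in the presence of a further agent that is not named here; on this read-out higher numbers stand for weaker inhibition and lower numbers for stronger inhibition:
- compound 1 `COc1ccc(Nc2ccc3ccccc3n2)cc1` gives 70000 nM
- compound 2 `Cc1ccc(-c2ccnc(Nc3ccc(F)cc3)c2)cc1` gives 146000 nM
- compound 3 `CCc1ccc(Nc2nc3ccccc3cc2-c2ccccc2)cc1` gives 66000 nM

Compound 2 has the highest number of the three (at 146000 nM) and lies beyond the scatter from both compound 1 and compound 3. The values of those other two lie within the scatter of each other.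

Compound 4 `COc1ccc(Nc2cc(-c3ccc(C)cc3)ccn2)cc1` keeps the core of compound 2 and differs from it in one place (methoxy in place of fluoro on an aromatic carbon): methoxy in place of fluoro on an aromatic carbon, para to a large group. Among the compounds with values here, no measured pair isolates this change. Compound 1 carries a methoxy group on another core and gives a lower number (70000 nM). Compound 3 goes against reading much into that, since it has no methoxy group and also gives a lower number (66000 nM). The expected step of a 1.5-fold lower number from compound 2 to compound 4 (0.16 log units; within the scatter) is therefore small, toward a lower number and within the scatter. For compound 4 the estimated value is 100000 nM (expected range 50000 nM to 200000 nM).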

Compound 4, half-maximal inhibitory concentration: 34000 nM
Compound 4: the middle estimate sits 2.9-fold (0.47 log units) above what was measured; measured number below the stated range.
By their numbers in this assay, from the lowest: compounds 4, 3 and 1 (each within the scatter of the next, the first and the last beyond it); then compound 2.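

In this assay, within the data shown here, methoxy in place of fluoro on an aromatic carbon, para to a large group, gives a 4.3-fold lower number from compound 2 to compound 4 (0.63 log units; beyond the scatter) on the shared core, the first direct reading of this change. The step lies beyond the scatter, so this position is not silent to the exchange, which compound 1 and compound 3 could not show without a matched partner. No measurement at hand accounts for the size of the step.

Going by these compounds, whether the step comes from gaining methoxy or from losing fluoro stays open, and an ethoxy group, a hydroxyl group or an amine at the same place would help separate the two. On these data alone, whether the same exchange gives a step of similar size on another core also remains open.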